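This account rests on a few compounds, and the source may have more. Where it says the series, first, only, none or still open, it means among the compounds named here.

Compound 1 `CC1CCC(=NNc2ccccc2)c2ncc(C(=O)O)c(=O)n21` gives 1.2 umol/kg in a functional assay on the whole organism for inhibition, with Rattus norvegicus as the target; on this read-out higher numbers stand for an effect only at larger amounts of compound and lower numbers for an effect already at smaller amounts. Compound 2 `CC1CC/C(=N\Nc2ccccc2Br)c2ncc(C(=O)O)c(=O)n21` reaches only the limit > 320 umol/kg in this assay. Compound 3 `CCOc1ccc(N/N=C2\CC[C@@H](C)n3c2ncc(C(=O)O)c3=O)cc1` reaches only the limit > 100 umol/kg in this assay.

On these numbers compound 2 stands at a limit rather than a value. Compound 3 stands at another limit. Compound 1 alone carries a number. Compound 4 `Cc1cccc(N/N=C2\CCC(C)n3c2ncc(C(=O)O)c3=O)c1` differs from compound 2 by 3-methylphenyl in place of 2-bromophenyl on an amine nitrogen. Going by the values given here, no measured step joins two compounds that differ in one place, so the expected size rests on the three values as they stand. Because compound 1 gives 1.2 umol/kg with an unsubstituted phenyl, compound 4 is expected to show inhibition at a smaller dose, a drop an at least 32-fold lower number from compound 2 to compound 4 (1.50 log units; beyond the scatter) beyond the scatter. Compound 4 is estimated at 10 umol/kg, between 1 umol/kg and 160 umol/kg.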

Compound 4, dose for 50% inhibition: 72.5 umol/kg
For compound 4 the middle estimate is 7.3-fold (0.86 log units) below the measured one; the range from low to high includes it.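

In this assay, 3-methylphenyl on the amine nitrogen yields a measured dose where 2-bromophenyl did not, a change of an at least 4.4-fold lower number from compound 2 to compound 4 (0.64 log units; beyond the scatter). Compound 2 stands at a limit, > 320 umol/kg, so this step gives only the smallest possible size of the change. A substituted phenyl can therefore keep a measurable dose here, which the earlier compounds had shown only for the unsubstituted phenyl of compound 1.

From the compounds shown here alone, it remains open whether the identity of the substituent or its place on the ring decides the outcome. A 3-bromophenyl or 2-methylphenyl group on the same nitrogen would separate the two.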